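The source may report more compounds than this note shows. Statements on the series, on what has been measured and on what is new or still open speak of the compounds shown alone.

Compound 1 `COC(=O)C1=C(C)NC(=O)NC1c1ccoc1`: 8%
Compound 2 `CC1=C(C(=O)C2CC2)C(c2ccoc2)NC(=O)N1`: 1%
Compound 3 `CC1=C(C(=O)CC(C)C)C(c2ccoc2)NC(=O)N1`: 23%

Of the compounds shown here, three built on one shared core have been tested in an assay on membranes from CHO cells for displacement of a labelled ligand from adenosine receptor A1 (Homo sapiens), read by scintillation counting, with a stated time of 60 min, tested at 1 uM; on this read-out lower numbers stand for less inhibition and higher numbers for more inhibition at the one concentration tested (going by the name of the read-out). Compound 2 gives the lowest of the three numbers, though it is not clearly set apart from every neighbour: the step of a number 7 percentage points lower from compound 1 to compound 2 (within the scatter) lies within the scatter, whereas the step of a number 22 percentage points higher from compound 2 to compound 3 (beyond the scatter) lies beyond it. A further step, a number 15 percentage points higher from compound 1 to compound 3 (beyond the scatter), also lies beyond the scatter. Every one of these measured steps exchanges the group on the carbonyl carbon and leaves the five-membered ring untouched.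

Compound 4 `CC1=C(C(=O)C2CC2)C(c2ccsc2)NC(=O)N1` has not yet been measured. It differs from compound 2 in one place: thiophen-3-yl in place of furan-3-yl on a saturated ring carbon. For the measured compounds named here, no measured step alters this ring, so none of them bears directly on this change; the measured series gives no size or direction for it. Without such guidance the plain expectation is a step that stays within the scatter, with the number for compound 4 expected to remain near the value of compound 2, that is a number 4 percentage points higher from compound 2 to compound 4 (within the scatter). The estimate for compound 4 in this assay is therefore 5%, expected to fall between -5% and 20%.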

Compound 4, a percentage reported as inhibition, at one concentration (the size of the read-out at that concentration, not a potency): 2%
Compound 4: the middle estimate sits 3 percentage points above what was measured; the range from low to high includes it.
By their numbers in this assay, from the lowest: compounds 2, 4 and 1 (each within the scatter of the next); then compound 3.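

Thiophen-3-yl in place of furan-3-yl on the saturated ring carbon is the first measured change at this position, and in this assay it gives a number 1 percentage points higher from compound 2 to compound 4 (within the scatter). With the cyclopropylcarbonyl group held fixed, exchanging the ring oxygen for sulfur therefore leaves no readable mark on this read-out, although compound 2 (1%) and compound 4 (2%) both sit so close to zero that there was little room for any fall to show. Nothing measured here speaks to why the two rings read alike.

From the compounds shown here alone, whether thiophen-3-yl would also read like furan-3-yl alongside the isobutyl group of compound 3 (23%), where there is more of a signal to lose or gain, remains open. The compounds shown also compare only two five-membered aromatic rings at this position, so they say nothing about a larger ring such as phenyl or pyridine, or about a ring carrying an amine or a carboxylic acid.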